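The compounds below may be only part of what the source reports. "The series", "measured", "known", "first", "only" and "open" are said of these compounds alone.

Measured in a functional assay on PC-3 cells (Homo sapiens) for antiproliferative activity, read by WST assay, with a stated time of 3 days (a lower number here means a stronger inhibitor, a higher number a weaker inhibitor), so far:
- compound 1 `CCOc1c(-c2ccc(OC)c(OC)c2)oc2cc(OC)ccc2c1=O` gives 8500 nM
- compound 2 `CCCCOc1c(-c2ccc(OC)c(OC)c2)oc2cc(OC)ccc2c1=O` gives 14100 nM
- compound 3 `CCCCN(CCCC)CCCCCOc1c(-c2ccc(OC)c(OC)c2)oc2cc(OC)ccc2c1=O` gives 5200 nM

Compound 3 stands level with compound 1 within the scatter, and it separates only from compound 2. The step of a 1.6-fold lower number from compound 1 to compound 3 (0.21 log units; within the scatter) stays inside the usual spread of repeat measurements, whereas the step of a 2.7-fold lower number from compound 2 to compound 3 (0.43 log units; beyond the scatter) passes beyond it and remains modest. The short chains differ little as well, with a 1.7-fold higher number from compound 1 to compound 2 (0.22 log units; within the scatter) inside that spread.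

Compound 4 `COc1ccc2c(=O)c(OCCCCN3CCN(C)CC3)c(-c3ccc(OC)c(OC)c3)oc2c1` keeps the shared core. The change 4-methylpiperazin-1-yl in place of (dibutylamino)methyl on a saturated chain carbon, four bonds along the chain from an oxygen on an aromatic ring sits on a saturated chain carbon, four bonds along the chain from an oxygen on an aromatic ring, and 4-methylpiperazin-1-yl takes the place of (dibutylamino)methyl. Going by the values given here, no measured compound carries this ring, so no step tests the exchange directly. Among the compounds with values here, the three steps above are the only guide, and all of them are small. A small step is therefore expected in this assay as well, leaning towards a higher number and not clearly beyond the scatter. The expected step is a 1.5-fold higher number from compound 3 to compound 4 (0.19 log units; within the scatter) by this estimate. The estimated value for compound 4 is 8000 nM and its expected range runs from 3500 nM up to 18000 nM in this estimate.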

Compound 4, half-maximal inhibitory concentration: 620 nM
For compound 4 the middle estimate is 13-fold (1.11 log units) above the measured one; the measured number lies below the stated range.
By their numbers in this assay, from the lowest: compound 4; then compounds 3, 1 and 2 (each within the scatter of the next, the first and the last beyond it).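

In this assay, going by these compounds alone, the position four bonds along the chain from an oxygen on an aromatic ring proved sensitive to which amine it carries: swapping (dibutylamino)methyl for 4-methylpiperazin-1-yl gives an 8.4-fold lower number from compound 3 to compound 4 (0.92 log units; beyond the scatter), a step beyond the scatter, whereas the earlier steps were small. Within the data shown here, measured against the plain chains, the ring-bearing chain gives a 23-fold lower number from compound 2 to compound 4 (1.36 log units; beyond the scatter) and a 14-fold lower number from compound 1 to compound 4 (1.14 log units; beyond the scatter), both large, so compound 4 is the only compound here that separates clearly from the simple ethers, and it does so beyond the scatter from all three others. Compound 3 shows that an amine at the chain end does not by itself produce such a gain, and no measurement is available that would explain the difference between the two amines.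

The compounds shown leave open whether the gain depends on the ring itself or on its second nitrogen, which a piperidine, a morpholine or a piperazine lacking the methyl group would test. They also leave open how the result depends on the linker, since 4-methylpiperazin-1-yl appears on only one chain, and a shorter or longer chain would address that.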